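Solubility notes: cyclohexyl for benzyloxy in compound 4

The source may hold more compounds than are shown below. What is called first, only, known or untested is meant among the compounds shown, and "the series" means these compounds.

Measured so far in a physicochemical assay for solubility, read by spectrophotometry, in phosphate buffer, with a stated time of 2 h, at pH 7.4; a lower number here means a less soluble compound, a higher number a more soluble compound:
compound 1 `COc1cccc(CN2C(=O)CN(C(=O)c3cc4cc(OC)ccc4[nH]3)C[C@@H]2COCc2ccccc2)c1` — 11700 nM
compound 2 `COc1ccc2[nH]c(C(=O)N3CC(=O)N(Cc4ccccc4)[C@@H](COCc4ccccc4)C3)cc2c1` — 8800 nM
compound 3 `COc1ccc2[nH]c(C(=O)N3CC(=O)N(c4ccccc4)[C@@H](Cc4ccccc4)C3)cc2c1` — 36100 nM

Compound 1 holds the second highest of the three numbers; compound 2 sits within the scatter of it (a 1.3-fold lower number from compound 1 to compound 2 (0.12 log units; within the scatter)), while compound 3 gives a number that is beyond the scatter higher. Compound 4 `COc1cccc(CN2C(=O)CN(C(=O)c3cc4cc(OC)ccc4[nH]3)C[C@@H]2CC2CCCCC2)c1` differs from compound 1 by cyclohexyl in place of benzyloxy on a saturated chain carbon bound to a saturated ring carbon. Going by the values given here, no measured step covers this change: the only single-point step, from compound 1 to compound 2, is a change elsewhere and lies within the scatter, and compound 3 differs from compound 1 in several places at once. The estimate for compound 4 therefore rests on compound 1 alone, with a wide range; a modest drop in this assay is expected, a 2.3-fold lower number from compound 1 to compound 4 (0.37 log units; beyond the scatter), giving an estimated 5000 nM (range 1500 nM to 15000 nM).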

Compound 4, solubility: 21400 nM
Beside the measured number, compound 4's estimate is 4.3-fold (0.63 log units) below it; measured number outside the range, above it.
By their numbers in this assay, from the lowest: compounds 2, 1, 4 and 3 (each within the scatter of the next, the first and the last beyond it).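

At the place on a saturated chain carbon bound to a saturated ring carbon, cyclohexyl in place of benzyloxy gives a 1.8-fold higher number from compound 1 to compound 4 (0.26 log units; within the scatter) in this assay. Going by these compounds alone, this is the first single-point step at this position, and the exchange of the aromatic ring for a non-aromatic one, with the hydrogen-bond acceptor leaving, stays within the scatter. Nothing on hand accounts for this result.

On these data alone, whether an amine or a carboxylic acid at this position would move the number beyond the scatter remains open. Also open, as far as these compounds go, is whether a longer chain would do so.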